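Flipping one ring stereocentre on the cyclopropyl amide

A few compounds are considered here, and "the series" means these few. Any claim that something is new, unique, unknown or untested is made for them only; others in the source may bear on it.

Compound 3 `C[C@H]1C[C@H]1C(=O)N1CC2CC(C1)N2` stands lowest in an assay on CHO cells for agonist activity at Neuronal acetylcholine receptor; alpha3/alpha6/beta2/beta3 (Homo sapiens), read by FLIPR and calcium flux (on this read-out lower numbers stand for smaller maximal responses and higher numbers for larger maximal responses), with 60%, beneath compound 2 `O=C([C@H]1C[C@@H]1F)N1CC2CC(C1)N2` at 85% and compound 1 `CC(=O)N1CC2CC(C1)N2` at 100%. The downward steps were a number 15 percentage points lower from compound 1 to compound 2 (beyond the scatter), a number 40 percentage points lower from compound 1 to compound 3 (beyond the scatter) and a number 25 percentage points lower from compound 2 to compound 3 (beyond the scatter), each exchanging the group on the carbonyl carbon. Compound 4 `C[C@H]1C[C@@H]1C(=O)N1CC2CC(C1)N2` differs from compound 3 in another way: the two compounds have the same atoms and bonds; at least one stereo element is drawn with a configuration in one of them and without one in the other: 1 of 4 stereo elements differ; a stereocentre at a saturated ring carbon is drawn R in compound 3 and S in compound 4. For the measured compounds named here, no measured step in this assay inverts a stereocentre while keeping every atom and bond, so none bears on this change directly; the measured steps show only that the group on the carbonyl carbon can move the response. Compound 4 is therefore expected to sit close by, with an estimated step of a number 10 percentage points higher from compound 3 to compound 4 (within the scatter) that may stay within the scatter. The estimate for compound 4 in this assay is 70%, ranging from 45% to 95%.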

Compound 4, largest response reached (Emax), in percent of the reference or control that the assay uses: 64%
Beside the measured number, compound 4's estimate is 6 percentage points above it; the range from low to high includes it.
By their numbers in this assay, from the lowest: compounds 3 and 4 (each within the scatter of the next); then compound 2; then compound 1.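

In this assay the inverted stereocentre at the saturated ring carbon gave a number 4 percentage points higher from compound 3 to compound 4 (within the scatter), so this one change separates the two methyl compounds by no more than the scatter. The replacements still register with either drawing: methyl in place of fluoro on a saturated ring carbon gives a number 21 percentage points lower from compound 2 to compound 4 (beyond the scatter) and 2-methylcyclopropyl in place of methyl on a carbonyl carbon gives a number 36 percentage points lower from compound 1 to compound 4 (beyond the scatter). One limit applies to the stereo comparison: the fact that one of compounds 3 and 4 is drawn with a defined configuration and the other without, at the place where they differ.

The compounds shown leave open whether an ethyl or a hydroxymethyl group at this ring carbon would respond to the same inversion.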